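The source may report more compounds than this note shows. Statements on the series, on what has been measured and on what is new or still open speak of the compounds shown alone.

Compound 1 `C/C=C/COC(=O)CCCN1C(=O)NC(c2ccc(Cl)cc2Cl)C(C(=O)OCc2ccccc2)=C1C` and compound 2 `COC(=O)CCCCN1C(=O)NC(c2ccc(Cl)cc2Cl)C(C(=O)OCc2ccccc2)=C1C` share one core and were both tested in an ADME assay on MCF7 cells (Homo sapiens) for cytotoxicity, read by CellTiter-Glo, with a stated time of 24 h; on this read-out higher numbers stand for weaker inhibition of growth and lower numbers for stronger inhibition of growth. In this assay compound 1 gives > 100000 nM, which is a limit of the assay and not a number. In this assay compound 2 likewise gives > 100000 nM, again a limit rather than a number. Among the compounds with values here, the single measured step, a step that the two limits leave unreadable from compound 1 to compound 2, therefore cannot be sized, since both of its values sit at the limit of > 100000 nM in this assay, at which 2 of the 2 values shown sit. Compound 2 thus stands at the weakest end that this assay can report. Compound 3 `CC1=C(C(=O)OCc2ccccc2)C(c2ccc(Cl)cc2Cl)NC(=O)N1CCCC(=O)OCc1ccccn1` is not yet measured; it differs from compound 2 by ((pyridin-2-yl)methoxy)carbonyl in place of (methoxycarbonyl)methyl on a saturated chain carbon, three bonds along the chain from an amide-type nitrogen in a ring. Within the data shown here, the one measured step bears on this change only loosely, and its size is unreadable, so no shift beyond the scatter is expected. For compound 3 the value expected in this assay is 150000 nM, within a range from 40000 nM to 600000 nM, most likely reported again as a limit. The step that this estimate means, a step that the limit leaves unreadable from compound 2 to compound 3, is expected to be none beyond the scatter.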

Compound 3, concentration for 50% growth inhibition: > 100000 nM
Compound 3: only a limit was reported; the forecaster's own chance of this, stated with the estimate: 85%; the middle value lies beyond the limit too.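

Within the data shown here, no step can be sized among compound 1, compound 2 and compound 3, because all three stop at one limit rather than a number: the limit of > 100000 nM in this assay, at which 3 of the 3 values shown sit. The compounds shown leave open whether changing the ester on this chain alters growth inhibition at all.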